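This account rests on a few compounds, and the source may have more. Where it says the series, first, only, none or still open, it means among the compounds named here.

Measured in a functional assay on HeLa cells (Homo sapiens) for cytotoxicity, read by MTT assay; on this read-out lower numbers stand for stronger inhibition and higher numbers for weaker inhibition:
- compound 1 `CC(C)=CC[C@@H](OC[C@H](C)O)C1=CC(=O)c2c(O)ccc(O)c2C1=O`: 40300 nM
- compound 2 `COC(C)CO[C@H](CC=C(C)C)C1=CC(=O)c2c(O)ccc(O)c2C1=O`: 53400 nM
- compound 3 `CC(C)=CC[C@@H](OC[C@@H](C)O)C1=CC(=O)c2c(O)ccc(O)c2C1=O`: 22500 nM

Compound 3 cannot be separated from its stereoisomer: a 1.8-fold lower number from compound 1 to compound 3 (0.25 log units; within the scatter). It does stand apart from the methoxy analogue: a 2.4-fold lower number from compound 2 to compound 3 (0.38 log units; beyond the scatter).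

Compound 4 `CC(=O)OCCC(=O)O[C@H](CC=C(C)C)C1=CC(=O)c2c(O)ccc(O)c2C1=O` carries (2-acetoxyethyl)carbonyl in place of 2-hydroxypropyl on an oxygen on a saturated carbon.

Among the compounds with values here, no measured step makes a change of this kind. The closest are a 1.3-fold higher number from compound 1 to compound 2 (0.12 log units; within the scatter) and a 2.4-fold lower number from compound 2 to compound 3 (0.38 log units; beyond the scatter), both inside the group that leaves, and both small. On that basis, no step beyond the scatter is expected in this assay, though with wide uncertainty. The expected step is a 1.3-fold lower number from compound 3 to compound 4 (0.10 log units; within the scatter).

The estimate for compound 4 is 18000 nM, with an expected range of 5000 nM to 50000 nM.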

Compound 4, half-maximal inhibitory concentration: 17300 nM
Compound 4: middle estimate off by 1.0-fold (0.02 log units), on the high side, and the stated range covers the measured number.
By their numbers in this assay, from the lowest: compounds 4, 3, 1 and 2 (each within the scatter of the next, the first and the last beyond it).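

On an oxygen on a saturated carbon, (2-acetoxyethyl)carbonyl replaces 2-hydroxypropyl in this assay without a step beyond the scatter: a 1.3-fold lower number from compound 3 to compound 4 (0.11 log units; within the scatter). Other comparisons give a 2.3-fold lower number from compound 1 to compound 4 (0.37 log units; beyond the scatter) and a 3.1-fold lower number from compound 2 to compound 4 (0.49 log units; beyond the scatter), showing that this place accepts a group of 8 heavy atoms with 0 hydrogen-bond donors. The reading depends on which stereoisomer serves as the reference, and those two references are closely related: the fact that compounds 1 and 3 differ only in the configuration as drawn. Still open, from the compounds shown here alone, is whether an amine or a carboxylic acid on this oxygen would shift the number further. Going by these compounds, a longer chain remains equally open.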